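Cyano on the sulfonyl ring: an expected cytotoxicity outcome

The source may report more compounds than this note shows. Statements on the series, on what has been measured and on what is new or still open speak of the compounds shown alone.

Of the compounds shown here, two have been measured so far in an ADME assay on L02 cells (Homo sapiens) for cytotoxicity, read by MTT assay, with a stated time of 24 h; on this read-out lower numbers stand for stronger inhibition and higher numbers for weaker inhibition. Compound 1 `O=C1/C(=C/c2ccccc2F)CN(S(=O)(=O)c2ccc(Br)cc2)C/C1=C\c1ccccc1F` gives 16200 nM in this assay. Compound 2 `O=C1/C(=C/c2cccc(F)c2)CN(S(=O)(=O)c2ccccc2)C/C1=C\c1cccc(F)c1` gives 16200 nM in this assay, level with compound 1 at the digits recorded, so the two values lie within the usual scatter of each other and nothing can be said of any order between them. Going by the values given here, since compound 1 and compound 2 differ at more than one place, no single step between measured compounds is available.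

Compound 3 `N#Cc1ccc(S(=O)(=O)N2C/C(=C\c3cccc(F)c3)C(=O)/C(=C/c3cccc(F)c3)C2)cc1` is not yet measured. It differs from compound 2 by one change: cyano in place of hydrogen on an aromatic carbon. The two values in hand give no indication of how such a change acts on this read-out, so the expected step is small, with no direction firmly favoured, and it may well remain within the scatter. The estimated step is a 1.2-fold lower number from compound 2 to compound 3 (0.06 log units; within the scatter). For compound 3 the expected value in this assay is 14000 nM, with a range from 6000 nM to 35000 nM.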

Compound 3, half-maximal inhibitory concentration: 15500 nM
Estimate against measurement, compound 3: 1.1-fold (0.04 log units) below; the measured number falls inside the stated range.
By their numbers in this assay, from the lowest: compounds 3, 1 and 2 (each within the scatter of the next).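

The change from phenylsulfonyl to (4-cyanophenyl)sulfonyl provides the only single-place comparison shown in this assay, with a 1.0-fold lower number from compound 2 to compound 3 (0.02 log units; within the scatter). At this place, on an aromatic carbon para to a large group, replacing hydrogen with cyano therefore leaves the number within the scatter, so this read-out does not separate compound 3 from compound 2. No supporting measurement bears on why the two compounds read alike.

The compounds shown leave open whether an amine, a carboxylic acid or a methoxy group at this same place would also stay within the scatter of compound 2, or whether any of them would move the number clearly in either direction. Going by these compounds alone, they also leave open whether cyano would read the same way at another place on the shared core, since this single pair speaks only for the one position and the one change.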